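The source may report more compounds than this note shows. Statements on the series, on what has been measured and on what is new or still open speak of the compounds shown alone.

Measured compounds:
compound 1 `CN1CCN(CCCN(C[C@H]2Cc3ccccc3CN2)[C@H]2CCCc3cccnc32)CC1` — 125 nM
compound 2 `c1ccc2c(c1)CN[C@@H](CN(CC[C@H]1CCCNC1)[C@H]1CCCc3cccnc31)C2` — 16 nM
compound 3 `CCN1CCN(CCCN(C[C@H]2Cc3ccccc3CN2)[C@H]2CCCc3cccnc32)CC1` — 33 nM

In a functional assay on CCRF-CEM cells for antagonist activity at C-X-C chemokine receptor type 4 (Homo sapiens), read by calcium flux, with stated times of 25 min and 90 s (a lower number here means a stronger inhibitor, a higher number a weaker inhibitor), compound 3 stands second highest of the three numbers: compound 2 sits nearest with a lower number, and compound 1 furthest with a higher one. Compound 4 `c1ccc2c(c1)CN[C@@H](CN(CCN1CCNCC1)[C@H]1CCCc3cccnc31)C2` is not yet measured; it differs from compound 3 by piperazin-1-yl in place of (4-ethylpiperazin-1-yl)methyl on a saturated chain carbon, two bonds along the chain from an amine nitrogen. For the measured compounds named here, two measured steps bear on this change. The step of a 3.8-fold lower number from compound 1 to compound 3 (0.58 log units; beyond the scatter) shows that lengthening the alkyl on the ring amine nitrogen lowered the number, so removing it altogether may move the number the other way. The step of a 2.1-fold higher number from compound 2 to compound 3 (0.31 log units; beyond the scatter) shows that a ring with a free amine nitrogen on a shorter chain gave a lower number. These pull in opposite directions, so for compound 4 a step of a 1.5-fold higher number from compound 3 to compound 4 (0.18 log units; within the scatter) in this assay is expected, within roughly the scatter. Compound 4 is therefore estimated at 50 nM, with a range from 15 nM to 170 nM.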

Compound 4, half-maximal inhibitory concentration: 553 nM
The estimate for compound 4 lay 11-fold (1.04 log units) below the measured number, outside the stated range (above it).
By their numbers in this assay, from the lowest: compound 2; then compound 3; then compound 1; then compound 4.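

In this assay piperazin-1-yl, on a saturated chain carbon, two bonds along the chain from an amine nitrogen, gave a 17-fold higher number from compound 3 to compound 4 (1.22 log units; beyond the scatter) and a 35-fold higher number from compound 2 to compound 4 (1.54 log units; beyond the scatter) and also a 4.4-fold higher number from compound 1 to compound 4 (0.65 log units; beyond the scatter) as its steps. So a ring with a free amine nitrogen does not by itself keep the number low at this position: piperidin-3-yl in compound 2 does, while piperazin-1-yl in compound 4 does not. Nothing at hand explains this loss.

The compounds shown leave open whether the loss follows the shorter chain or the unsubstituted piperazine, since compound 4 changes both at once. A 3-(piperazin-1-yl)propyl group or a 2-(4-methylpiperazin-1-yl)ethyl group would separate the two.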